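Working notes: 4-fluorobenzyl to 4-methylbenzyl

The source may hold more compounds than are shown below. What is called first, only, known or untested is meant among the compounds shown, and "the series" means these compounds.

In a functional assay on HeLa cells (Homo sapiens) for cytotoxicity, read by MTT assay, with a stated time of 48 h (a lower number here means a stronger inhibitor, a higher number a weaker inhibitor), compound 2 `O=C(O)CN1C(=O)/C(=C/c2nc3ccccc3n2Cc2ccc(F)cc2)SC1=S` gives 13900 nM and compound 1 `O=C(O)CN1C(=O)/C(=C/c2nc3ccccc3n2Cc2ccc([N+](=O)[O-])cc2)SC1=S` gives 18600 nM and the two lie within the scatter of each other. Compound 3 `Cc1ccc(Cn2c(/C=C3\SC(=S)N(CC(=O)O)C3=O)nc3ccccc32)cc1` has methyl in place of fluoro on an aromatic carbon, para to a large group (methyl in place of fluoro on an aromatic carbon). Within the data shown here, the one measured step at this place (a 1.3-fold lower number from compound 1 to compound 2 (0.13 log units; within the scatter)) put fluoro in place of nitro and stayed within the scatter, so no step beyond the scatter is expected in this assay here. Compound 3 is estimated at 14500 nM with 7000 nM to 30000 nM as the expected range. The expected step (a 1.0-fold higher number from compound 2 to compound 3 (0.02 log units; within the scatter)) stays within the scatter.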

Compound 3, half-maximal inhibitory concentration: 1280 nM
Estimate against measurement, compound 3: 11-fold (1.05 log units) above; measured number outside the range, below it.
By their numbers in this assay, from the lowest: compound 3; then compounds 2 and 1 (each within the scatter of the next).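

At this place, on an aromatic carbon para to a large group, the choice of group does move the number in this assay, which fluoro and nitro alone did not show. Methyl gives a large step against both earlier groups (an 11-fold lower number from compound 2 to compound 3 (1.04 log units; beyond the scatter); a 15-fold lower number from compound 1 to compound 3 (1.16 log units; beyond the scatter)), so compound 3 is the lowest of the three. Nothing available explains this step.

On these data alone, whether the gain is particular to methyl stays open. An ethyl, a methoxy or an amine at this place could separate those readings.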